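Replacing the Chain Amine of Compound 3

The compounds below may be only part of what the source reports. "The series", "measured", "known", "first", "only" and "open" are said of these compounds alone.

In a functional assay on NCI-H460 cells (Homo sapiens) for cytotoxicity, read by MTT assay, with a stated time of 72 h (on this read-out lower numbers stand for stronger inhibition and higher numbers for weaker inhibition), compound 1 `COc1cc2c(Oc3ccc(NC(=O)c4cn(-c5ccccc5)nn4)cc3F)ccnc2cc1OCCCN1CCCCC1` gives 210 nM.
In this assay, compound 2 `COc1cc2c(Oc3ccc(NC(=O)c4cn(-c5ccccc5C)nn4)cc3F)ccnc2cc1OCCCN1CCCCC1` gives 2100 nM.
In this assay, compound 3 `COc1cc2c(Oc3ccc(NC(=O)c4cn(-c5c(C)cccc5C)nn4)cc3F)ccnc2cc1OCCCN1CCCCC1` gives 3520 nM.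

Compound 3 stands highest of the three numbers: against compound 2 the gap a 1.7-fold higher number from compound 2 to compound 3 (0.22 log units; within the scatter) lies within the scatter, while against compound 1 the step of a 17-fold higher number from compound 1 to compound 3 (1.22 log units; beyond the scatter) lies beyond it. Compound 4 `COc1cc2c(Oc3ccc(NC(=O)c4cn(-c5c(C)cccc5C)nn4)cc3F)ccnc2cc1OCCCN1CCN(C)CC1` differs from compound 3 in one place: 4-methylpiperazin-1-yl in place of piperidin-1-yl on a saturated chain carbon, three bonds along the chain from an oxygen on an aromatic ring. The measured steps of a 10-fold higher number from compound 1 to compound 2 (1.00 log units; beyond the scatter) and a 17-fold higher number from compound 1 to compound 3 (1.22 log units; beyond the scatter) concern only the ring on the aromatic nitrogen; no measured step touches the chain amine, so nothing shown bears on this change. No step beyond the scatter is therefore expected in this assay for compound 4. Compound 4 is estimated at 3500 nM, with a range from 1200 nM to 10000 nM, which means an expected step of a 1.0-fold lower number from compound 3 to compound 4 (0.00 log units; within the scatter).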

Compound 4, half-maximal inhibitory concentration: 4540 nM
The estimate for compound 4 lay 1.3-fold (0.11 log units) below the measured number; measured number inside the range.
By their numbers in this assay, from the lowest: compound 1; then compounds 2, 3 and 4 (each within the scatter of the next, the first and the last beyond it).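

In this assay, among these compounds, the chain amine is now measured for the first time, and 4-methylpiperazin-1-yl in place of piperidin-1-yl gives a 1.3-fold higher number from compound 3 to compound 4 (0.11 log units; within the scatter) on the 2,6-dimethylphenyl series. At this position, then, the added ring nitrogen and its methyl leave the number within the scatter for this one pair. Nothing measured here offers an account of this result.

As far as these compounds go, whether morpholin-4-yl or an open-chain dimethylamino group at the end of the propyl chain would behave alike remains open. So does whether the same exchange would give a similar step on the plain phenyl of compound 1.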